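Swapping the piperidine arm: from compound 1 to compound 4

The source may hold more compounds than are shown below. What is called first, only, known or untested is meant among the compounds shown, and "the series" means these compounds.

Measured compounds:
compound 1, `c1ccc2c(c1)CN[C@@H](CN(CC1CCNCC1)[C@H]1CCCc3cccnc31)C2`: 13%
compound 2, `c1ccc2c(c1)CN[C@@H](CN(CC[C@H]1CCCNC1)[C@H]1CCCc3cccnc31)C2`: 56%
compound 3, `c1cnc2c(c1)CCC[C@@H]2N(CCCN1CCNCC1)Cc1cc2ccccc2cn1`: 74%

In an ADME assay on microsomes from liver (Mus musculus) for metabolic stability, read by LC-MS, with a stated time of 10 min, tested at 0.5 uM (on this read-out lower numbers stand for a less stable compound and higher numbers for a more stable compound), compound 1 gives 13%, the lowest reading among the three compounds. Compound 2 stands above it by a number 43 percentage points higher from compound 1 to compound 2 (beyond the scatter), a step beyond the scatter, and compound 3 with 74% stands further above still. Compound 4, `c1ccc2c(c1)CN[C@@H](CN(CC[C@@H]1CCCNC1)[C@H]1CCCc3cccnc31)C2`, differs from compound 1 in one place: (piperidin-3-yl)methyl in place of piperidin-4-yl on a saturated chain carbon bound to an amine nitrogen. Going by the values given here, only one measured step bears directly on this change, the one from compound 1 to compound 2, where the same group entered at the same place and the read-out rose by a number 43 percentage points higher from compound 1 to compound 2 (beyond the scatter), a large step. Among the compounds with values here, compound 4 differs from compound 2 only in the defined stereocentre of the entering group, and no measurement shows what that stereocentre does on its own, so the outcome is less certain than the single step suggests. A rise beyond the scatter is nevertheless the expectation for compound 4, estimated as a number 32 percentage points higher from compound 1 to compound 4 (beyond the scatter). Compound 4 is therefore expected to give about 45%, within a range from 20% to 70%.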

Compound 4, percent of the compound remaining: 23%
The estimate for compound 4 lay 22 percentage points above the measured number; measured number inside the range.
By their numbers in this assay, from the lowest: compounds 1 and 4 (each within the scatter of the next); then compound 2; then compound 3.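

Placing (piperidin-3-yl)methyl on a saturated chain carbon bound to an amine nitrogen does not by itself guarantee a clear gain in this assay: the step is a number 10 percentage points higher from compound 1 to compound 4 (within the scatter). The large rise seen earlier therefore cannot be credited to the group alone, and its drawn configuration also counts, as the comparison of the two mirror-drawn forms of the group gives a number 33 percentage points lower from compound 2 to compound 4 (beyond the scatter). This gap can be assigned to the stereocentre at the saturated ring carbon, drawn R in compound 2 and S in compound 4, because nothing else in the structures changes: the fact that compounds 2 and 4 differ only in the configuration as drawn

The compounds shown contain only this one pair of configurations, so it remains open whether a similar gap would appear with a (pyrrolidin-3-yl)methyl group or with a longer chain between the piperidine ring and the amine nitrogen. They also leave open why the two configurations give such different readings, since the numbers show the size of the gap and not the process behind it.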